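Ester and Acid Compared in a Lipoxygenase Series

The source may report more compounds than this note shows. Statements on the series, on what has been measured and on what is new or still open speak of the compounds shown alone.

Three compounds have been measured in an assay for inhibition of Polyunsaturated fatty acid 5-lipoxygenase (Homo sapiens), tested at 1 uM; on this read-out lower numbers stand for a stronger effect and higher numbers for a weaker effect at the one concentration tested:

compound 1 `CCCCC(Sc1nc(Cl)cc(Nc2ccc3ncccc3c2)n1)C(=O)OCC`: 51.8%
compound 2 `CCCCCCC(Sc1nc(Cl)cc(Nc2cccc(C)c2C)n1)C(=O)OCC`: 84.9%
compound 3 `CCOC(=O)CSc1nc(Cl)cc(Nc2cccc3c2CCC3)n1`: 65.2%

Compound 1 stands at the lowest of the three numbers, which on this read-out means the strongest effect at the single concentration tested. Its nearest neighbour is compound 3, whose number lies higher by an amount beyond the usual scatter, and compound 2 sits further away still, also beyond the scatter. No two of these compounds differ in only one place, so no single structural step can be read from the measured values.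

The unmeasured compound 4 `CCCCC(Sc1nc(Cl)cc(Nc2ccc3ncccc3c2)n1)C(=O)O` is the partner of compound 1 in such a step: hydrogen in place of ethyl on an oxygen next to a carbonyl group. Put another way, the ethoxycarbonyl becomes a carboxy group, and everything else in the molecule stays the same.

Among the compounds with values here, no measured pair shows what this kind of change does in this assay, so any expectation rests on the change alone. The step from an ester to the free acid is expected to be modest, with a slightly higher number, close to the edge of the scatter. The estimated step of a number 8.2 percentage points higher from compound 1 to compound 4 (within the scatter) carries a wide range in either direction. On this basis compound 4 is expected to give 60%, within a range from 35% to 85%.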

Compound 4, a percentage reported as activity, at one concentration (the size of the read-out at that concentration, not a potency): "not active" (no number reported)
Compound 4 has no reported number here; there is nothing to compare the estimate with.
By their numbers in this assay, from the lowest: compound 1; then compound 3; then compound 2.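

In this assay, within the data shown here, compound 4 is reported as not active, with no number, so no step from compound 1 to compound 4 can be read. No evidence at hand bears on this result. The compounds shown leave open how far the change from ethoxycarbonyl to carboxy moves the read-out, and whether it does the same on other members of the series.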